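This account rests on a few compounds, and the source may have more. Where it says the series, first, only, none or still open, it means among the compounds named here.

The three measured compounds share one core and differ only in the chain on its aromatic carbon. Compound 1 `CCc1cn([C@H]2C[C@@H]3OP(=O)(O)OC[C@H]3O2)c(=O)[nH]c1=O` carries an ethyl group, compound 2 `CC(C)c1cn([C@H]2C[C@@H]3OP(=O)(O)OC[C@H]3O2)c(=O)[nH]c1=O` an isopropyl group and compound 3 `CCCCCc1cn([C@H]2C[C@@H]3OP(=O)(O)OC[C@H]3O2)c(=O)[nH]c1=O` a pentyl group. In a functional assay on L1210 cells (Mus musculus) (on this read-out higher numbers stand for weaker inhibition and lower numbers for stronger inhibition), compound 1 gives only a limit, > 500 ug/mL. In this assay compound 2 also gives only a limit, > 500 ug/mL. In this assay compound 3 likewise gives only a limit, > 500 ug/mL. The steps between them therefore cannot be sized: a step that the two limits leave unreadable from compound 1 to compound 3 and a step that the two limits leave unreadable from compound 2 to compound 3, the latter being (pentyl in place of isopropyl on an aromatic carbon).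

Compound 4 `CCCCc1cn([C@H]2C[C@@H]3OP(=O)(O)OC[C@H]3O2)c(=O)[nH]c1=O` has not been measured. It differs from compound 3 by hydrogen in place of methyl on a saturated chain carbon, four bonds along the chain from an aromatic carbon. The same kind of change, (hydrogen in place of methyl on a saturated chain carbon bound to an aromatic carbon and a saturated chain carbon), relates compound 2 to compound 1, where the step is a step that the two limits leave unreadable from compound 2 to compound 1. The surroundings of the place differ: in the measured pair the carbon is bound to an aromatic carbon and a saturated chain carbon, whereas in compound 4 it sits four bonds along the chain from an aromatic carbon, so the change is of the same kind, not the same. The cores differ by the chain just described.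

Because every measured compound sits at the limit of > 500 ug/mL in this assay, at which 3 of the 3 values shown sit, the step from compound 3 to compound 4 is expected to be a step that the limit leaves unreadable from compound 3 to compound 4. Compound 4 is expected to give about 600 ug/mL in this assay, most probably again as a limit. The expected range for compound 4 runs from 300 ug/mL to 2000 ug/mL.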

Compound 4, concentration for 50% inhibition: 33.5 ug/mL
Compound 4: the middle estimate sits 18-fold (1.25 log units) above what was measured, outside the stated range (below it).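

In this assay the change of hydrogen in place of methyl on a saturated chain carbon, four bonds along the chain from an aromatic carbon, turns the pentyl compound into the butyl compound and gives an at least 14-fold lower number from compound 3 to compound 4 (1.17 log units; beyond the scatter) on this one chain, and compound 4 stands equally clear of the other two, with an at least 14-fold lower number from compound 2 to compound 4 (1.17 log units; beyond the scatter) and an at least 14-fold lower number from compound 1 to compound 4 (1.17 log units; beyond the scatter) as the other steps. Among these compounds, this does not show that the change carries over to another core: the only other pair with the same kind of change, compound 2 and compound 1, has the methyl at a different place, and its step, like every step among compounds 1, 2 and 3, cannot be read. No size can be set for that pair, and no trend with chain length can be claimed, because the three other compounds all rest on one limit: the limit of > 500 ug/mL in this assay, at which 3 of the 4 values shown sit.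

The compounds shown leave open whether the result belongs to the butyl chain alone or extends to neighbouring chains such as propyl or hexyl on the aromatic carbon. They also leave open whether a butyl chain carrying an amine or a carboxylic acid would stay with compound 4 or fall back to the limit.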